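The source may report more compounds than this note shows. Statements on the series, on what has been measured and on what is new or still open speak of the compounds shown alone.

Measured compounds:

Compound 1, `CONC(=O)[C@@H]1CC=C(CCC=C(C)C)C[C@H]1c1ccccc1`: 2700 nM
Compound 2, `CC(C)=CCCC1=CC[C@H](C(=O)NO)[C@@H](c2ccccc2)C1`: 600 nM

Of the compounds shown here, two have been measured in an assay on isolated protein for inhibition of Apoptosis regulator Bcl-2 (Homo sapiens), read by fluorescence polarization, with stated times of 5 min and 10 min; on this read-out higher numbers stand for weaker inhibition and lower numbers for stronger inhibition. Compound 1 gives 2700 nM, and compound 2 gives 600 nM, the lower of the two numbers and thus the stronger inhibitor, with a gap that lies beyond the usual scatter.

Compound 3, `CONC(=O)[C@H]1CC=C(CCC=C(C)C)C[C@@H]1c1ccccc1`, has not been measured yet. It differs from compound 2 in one place: methyl in place of hydrogen on an oxygen, turning the hydroxycarbamoyl group into a methoxycarbamoyl group.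

Going by the values given here, no measured pair shows this change directly, so the expectation rests on the measured values only. Compound 1, which also carries a methoxycarbamoyl group, sits at the weaker end of the two numbers. The step from compound 2 to compound 3 is therefore expected to go towards weaker inhibition, by about a 5.0-fold higher number from compound 2 to compound 3 (0.70 log units; beyond the scatter). For compound 3 the estimated value in this assay is 3000 nM, with a likely range from 1000 nM to 9000 nM.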

Compound 3, inhibition constant: 2400 nM
Compound 3: middle estimate off by 1.3-fold (0.10 log units), on the high side, within the range that was stated.
By their numbers in this assay, from the lowest: compound 2; then compounds 3 and 1 (each within the scatter of the next).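

In this assay, going by these compounds alone, compounds 2 and 3 give the first direct reading of this change: placing a methyl on the oxygen, which turns the hydroxycarbamoyl group into a methoxycarbamoyl group, gives a 4.0-fold higher number from compound 2 to compound 3 (0.60 log units; beyond the scatter), a shift towards weaker inhibition that lies beyond the scatter. The new compound also forms a mirror-image pair with an earlier one, and that comparison reads a 1.1-fold lower number from compound 1 to compound 3 (0.05 log units; within the scatter), so inverting both stereocentres of the methoxycarbamoyl compound produces no difference that this measurement can resolve. That reading speaks to configuration alone, with no other structural change mixed in, because of a single point: the fact that compounds 1 and 3 differ only in the configuration as drawn.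

From the compounds shown here alone, the mirror-image comparison covers only the methoxycarbamoyl compounds, so it remains open whether the hydroxycarbamoyl group would be equally indifferent to configuration. Going by these compounds, it also remains open how inhibition would respond to other groups at this position, such as a carboxylic acid or an ethoxycarbamoyl group, and so whether the step seen with methyl is specific to that group.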